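This account rests on a few compounds, and the source may have more. Where it says the series, first, only, none or still open, it means among the compounds named here.

Measured in an ADME assay on MT4 cells (Homo sapiens) for cytotoxicity, read by MTT assay, with a stated time of 5 days; a higher number here means that more compound is tolerated, a lower number that less compound is tolerated:
- Compound 1 `Cc1cc(C)cc(S(=O)(=O)c2c(C(=O)N[C@H]3CCN(Cc4cccnc4)C3)[nH]c3ccc(Cl)cc23)c1`: 22800 nM
- Compound 2 `Cc1cc(C)cc(S(=O)(=O)c2c(C(=O)NC3CN(S(C)(=O)=O)C3)[nH]c3ccc(Cl)cc23)c1`: > 252000 nM, a limit of the assay and not a number
- Compound 3 `Cc1cc(C)cc(S(=O)(=O)c2c(C(=O)NC3CN(CC(N)=O)C3)[nH]c3ccc(Cl)cc23)c1`: 25500 nM

Within the data shown here, compound 3 sits level with compound 1, the only other exact number: a 1.1-fold higher number from compound 1 to compound 3 (0.05 log units; within the scatter). Its other measured step is an at least 9.8-fold lower number from compound 2 to compound 3 (0.99 log units; beyond the scatter).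

Compound 4 `Cc1cc(C)cc(S(=O)(=O)c2c(C(=O)NS(=O)(=O)C(F)(F)F)[nH]c3ccc(Cl)cc23)c1` has not yet been measured. Its difference is (trifluoromethyl)sulfonyl in place of 1-(carbamoylmethyl)azetidin-3-yl on an amide-type nitrogen.

Two measured steps changed the group at this same nitrogen, and they disagree in size: one is a 1.1-fold higher number from compound 1 to compound 3 (0.05 log units; within the scatter), the other at least 11-fold higher number from compound 1 to compound 2 (1.04 log units; beyond the scatter). Neither brings in (trifluoromethyl)sulfonyl. Compound 2 alone carries a sulfonyl group, as methylsulfonyl on an amine nitrogen in a ring, so it offers only a weak hint towards higher numbers. Among the measured compounds shown here, no step clearly beyond the scatter is therefore expected in this assay, with a slight lean upwards. The estimated step is a 1.6-fold higher number from compound 3 to compound 4 (0.20 log units; within the scatter). For compound 4 the expected value is 40000 nM, with an estimated range from 12000 nM to 180000 nM.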

Compound 4, half-maximal cytotoxic concentration: 141000 nM
Estimate against measurement, compound 4: 3.5-fold (0.55 log units) below; measured number inside the range.
By their numbers in this assay, from the lowest: compounds 1 and 3 (each within the scatter of the next); then compound 4. At a limit, above all of these: compound 2.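

In this assay, a group with no ring, (trifluoromethyl)sulfonyl, set directly on the amide-type nitrogen gives a 5.5-fold higher number from compound 3 to compound 4 (0.74 log units; beyond the scatter) and a 6.2-fold higher number from compound 1 to compound 4 (0.79 log units; beyond the scatter). Until now only compound 2 stood apart from compounds 1 and 3, so this is a second change at this position that clearly moves the number, and both compounds that stand apart carry a sulfonyl group, though in compound 2 it sits on an amine nitrogen in a ring. The step of an at least 1.7-fold lower number from compound 2 to compound 4 (0.25 log units; that floor lies within the scatter) cannot be read as a true size, because the value of compound 2 is a limit of the assay: the limit of > 252000 nM in this assay, at which 1 of the 4 values shown sits.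

The compounds shown leave open whether the sulfonyl group or its trifluoromethyl matters more at this nitrogen. A methylsulfonyl or an acetyl group placed directly on it would begin to separate the two.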